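Sulfonamide series: inverting the saturated ring stereocentre

A few compounds are considered here, and "the series" means these few. Any claim that something is new, unique, unknown or untested is made for them only; others in the source may bear on it.

Three compounds have been run in an assay on isolated protein for inhibition of phosphatidylinositol 4,5-bisphosphate 3-kinase catalytic subunit beta isoform (Homo sapiens); a higher number here means a weaker inhibitor, a lower number a stronger inhibitor. Compound 1 `Cc1ccc([N+](=O)[O-])cc1S(=O)(=O)C/C=C/c1cnn2ccc(Br)cc12` gives > 1000 nM, which is a limit of the assay rather than a number. Compound 2 `Cc1ccc([N+](=O)[O-])cc1S(=O)(=O)N1CCC(c2cnn3ccc(Br)cc23)C1` gives > 1000 nM, again a limit. Compound 3 `Cc1ccc([N+](=O)[O-])cc1S(=O)(=O)N[C@H]1CCN(Cc2cnn3ccc(C#N)cc23)C1` gives > 1000 nM, also a limit. Within the data shown here, compound 3 therefore stands, with the rest, at the limit of > 1000 nM in this assay, at which 3 of the 3 values shown sit, and no measured step between any two compounds exists on which a direction could rest. Compound 4 `Cc1ccc([N+](=O)[O-])cc1S(=O)(=O)N[C@@H]1CCN(Cc2cnn3ccc(C#N)cc23)C1` differs from compound 3 only in configuration: the two compounds have the same atoms and bonds and differ only in configuration as drawn: 1 of 1 stereo elements differ; a stereocentre at a saturated ring carbon is drawn S in compound 3 and R in compound 4. No size or direction can be drawn from the numbers shown, so the step is expected to be a step that the limit leaves unreadable from compound 3 to compound 4, and another limit is the likelier outcome. Compound 4 is estimated at 2000 nM, with a range from 400 nM to 10000 nM.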

Compound 4, half-maximal inhibitory concentration: > 1000 nM
Compound 4: only a limit was reported; the forecaster's own chance of this, stated with the estimate: 70%; the middle value does not contradict the limit.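

In this assay compound 4 gives > 1000 nM, a limit of the assay. Among these compounds, compound 3 sits at the same limit, so no step between compound 3 and compound 4 can be read. Whether the configuration at the saturated ring carbon affects inhibition remains open, since no compound shown gives a value beyond a limit.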